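This account rests on a few compounds, and the source may have more. Where it says the series, first, only, none or still open, it means among the compounds named here.

Within the data shown here, compound 1 `CNC(=O)c1cncc(NS(=O)(=O)c2cc(Cl)ccc2OC)c1` is one of two compounds measured in an assay on isolated protein for inhibition of alkaline phosphatase, tissue-nonspecific isozyme (Homo sapiens) (a lower number here means a stronger inhibitor, a higher number a weaker inhibitor), and compound 1 gives 109 nM, the higher of the two numbers. The other measured compound, compound 2 `COc1ccc(C(F)(F)F)cc1S(=O)(=O)Nc1cnc2ccccc2c1`, gives in this assay a value of 26 nM, a gap that lies beyond the usual scatter. Compound 2 carries a different core, so nothing about a single change can be read from the two values side by side. Compound 3 `COc1ccc(Cl)cc1S(=O)(=O)Nc1cncc(-c2cccc(C)c2)c1` has not yet been measured in this assay; it differs from compound 1 in one place only: 3-methylphenyl in place of methylcarbamoyl on an aromatic carbon. No step of this kind has been measured among the compounds shown, so the size of the change can only be guessed. A modest gain seems plausible, with the number for compound 3 expected to come out lower than that of compound 1, though not far beyond the scatter. For compound 3 the estimate in this assay is 55 nM, with a range from 15 nM to 200 nM. This estimate corresponds to an expected step of a 2.0-fold lower number from compound 1 to compound 3 (0.30 log units; within the scatter).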

Compound 3, half-maximal inhibitory concentration: 160 nM
The estimate for compound 3 lay 2.9-fold (0.46 log units) below the measured number; the measured number falls inside the stated range.
By their numbers in this assay, from the lowest: compound 2; then compounds 1 and 3 (each within the scatter of the next).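

In this assay, the first single change measured at this position gives a 1.5-fold higher number from compound 1 to compound 3 (0.17 log units; within the scatter). The position two atoms from the ring nitrogen therefore accepts 3-methylphenyl in place of methylcarbamoyl with no step beyond the scatter. In this pair, the number stays within the scatter when the hydrogen-bond donor and acceptor of methylcarbamoyl are gone and an aromatic ring of carbon stands in their place.

From the compounds shown here alone, whether an amine, a carboxylic acid or an unsubstituted phenyl at this position would move the number beyond the scatter remains open, as does whether this change would give a similar step on the core of compound 2. No measurement at hand explains why these two groups give numbers within the scatter of each other.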